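Swapping a hydroxypyrrolidine sulfonamide for an isopropyl sulfonamide

The compounds below may be only part of what the source reports. "The series", "measured", "known", "first", "only" and "open" are said of these compounds alone.

Three measured compounds share one core and differ only in the group attached to a sulfonyl sulfur. Compound 1 `O=C([C@@H]1CCCN(S(=O)(=O)c2ccc(S(=O)(=O)C3CCC3)cc2)C1)N1CCC(F)(F)CC1` carries a cyclobutyl there, compound 2 `CCC(CC)S(=O)(=O)c1ccc(S(=O)(=O)N2CCC[C@@H](C(=O)N3CCC(F)(F)CC3)C2)cc1` a pentan-3-yl, and compound 3 `O=C([C@@H]1CCCN(S(=O)(=O)c2ccc(S(=O)(=O)N3CC[C@H](O)C3)cc2)C1)N1CCC(F)(F)CC1` a 3-hydroxypyrrolidin-1-yl. In a functional assay on BXPC-3 cells (Homo sapiens) for inhibition, read by MTT assay, with a stated time of 7 days (on this read-out lower numbers stand for stronger inhibition and higher numbers for weaker inhibition), compound 1 gives 78 nM, compound 2 gives 40 nM, and compound 3 gives 580 nM. Compound 3 thus stands with the highest number of the three: a 7.4-fold higher number from compound 1 to compound 3 (0.87 log units; beyond the scatter) and a 15-fold higher number from compound 2 to compound 3 (1.16 log units; beyond the scatter), while a 2.0-fold lower number from compound 1 to compound 2 (0.29 log units; within the scatter).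

Compound 4 `CC(C)NS(=O)(=O)c1ccc(S(=O)(=O)N2CCC[C@@H](C(=O)N3CCC(F)(F)CC3)C2)cc1` is the next step from compound 3: isopropylamino in place of 3-hydroxypyrrolidin-1-yl on a sulfonyl sulfur. The two steps that bear on this change are the ones leading into compound 3, and both show that replacing a carbon-linked group on the sulfonyl sulfur with the hydroxypyrrolidine gave a clearly higher number. Compound 4 keeps a nitrogen on that sulfonyl sulfur but loses the ring and the hydroxyl, so in kind it matches neither the carbon-linked groups nor the hydroxypyrrolidine fully. A step back toward the lower numbers of compound 1 and compound 2 is therefore expected, though not necessarily all the way. Compound 4 is estimated at 250 nM in this assay, within 70 nM to 900 nM. For compound 4 this would mean an expected step of a 2.3-fold lower number from compound 3 to compound 4 (0.37 log units; beyond the scatter).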

Compound 4, half-maximal inhibitory concentration: 470 nM
Compound 4: middle estimate off by 1.9-fold (0.27 log units), on the low side; measured number inside the range.
By their numbers in this assay, from the lowest: compounds 2 and 1 (each within the scatter of the next); then compounds 4 and 3 (each within the scatter of the next).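

In this assay, isopropylamino in place of 3-hydroxypyrrolidin-1-yl gives a 1.2-fold lower number from compound 3 to compound 4 (0.09 log units; within the scatter), so removing the ring and the hydroxyl while keeping a nitrogen on the sulfonyl sulfur produces no readable change. Compound 4 stays well apart from the carbon-linked compounds, with a 12-fold higher number from compound 2 to compound 4 (1.07 log units; beyond the scatter) and a 6.0-fold higher number from compound 1 to compound 4 (0.78 log units; beyond the scatter), and across these four compounds the two with a nitrogen on the sulfonyl sulfur have clearly higher numbers than the two with a carbon there, with none going against this split. Nothing measured here accounts for that split.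

An isopropyl group placed directly on the sulfonyl sulfur would pair with compound 4 as a change of that one linking atom, and so would test whether the nitrogen itself goes with the higher numbers or whether the split depends on the rest of each group. Other nitrogen-linked groups, such as a plain amino group, dimethylamino or an unsubstituted pyrrolidin-1-yl, also remain open, so it is unknown how widely the higher numbers extend across that family.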